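The source may hold more compounds than are shown below. What is called first, only, known or untested is meant among the compounds shown, and "the series" means these compounds.

In an ADME assay on CEM-SS cells (Homo sapiens) for cytotoxicity, read by XTT assay, with a stated time of 6 days (on this read-out lower numbers stand for higher toxicity in this test and higher numbers for lower toxicity in this test), the measured set reads:
compound 2, `CCCC(=O)OCSc1ccccc1C(=O)NCCCCC(N)=O`: 51.7 uM
compound 3, `CCCC(=O)OCSc1ccccc1C(=O)Nc1cccc(C(N)=O)c1`: 17.5 uM
compound 1, `CCCC(=O)OCSc1ccc(OC(F)(F)F)cc1C(=O)NC(C)(C)C(N)=O`: < 56.1 uM, which is a limit of the assay and not a number

Compound 2 holds the higher of the two numbers in this assay; compound 3 sits lower, and the gap between them is beyond the usual scatter. Compound 1 is known only as a limit (the limit of < 56.1 uM in this assay, at which 1 of the 3 values shown sits), so it cannot be ranked against the other two.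

Among the compounds with values here, no pair of measured compounds differs in a single place, so no measured step in this assay can be carried over. The move from compound 2 to compound 4, `CCCC(=O)OCSc1ccccc1C(N)=O`, is hydrogen in place of 4-carbamoylbutyl on an amide-type nitrogen. In the words of the counted difference, 4-carbamoylbutyl leaves and hydrogen enters on the amide-type nitrogen whose other neighbour is the carbonyl carbon, a change for which the measured set offers no direct comparison.

The step from compound 2 to compound 4 in this assay is expected to be small and not beyond the scatter: a 1.2-fold higher number from compound 2 to compound 4 (0.06 log units; within the scatter). Compound 4 is estimated at 60 uM, with a range from 25 uM to 130 uM.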

Compound 4, half-maximal toxic concentration: 12.4 uM
Compound 4: middle estimate off by 4.8-fold (0.68 log units), on the high side, outside the stated range (below it).
By their numbers in this assay, from the lowest: compounds 4 and 3 (each within the scatter of the next); then compound 2.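

On this amide-type nitrogen whose other neighbour is the carbonyl carbon, the substituent is not silent in this assay: with hydrogen in place of 4-carbamoylbutyl, the read-out gives a 4.2-fold lower number from compound 2 to compound 4 (0.62 log units; beyond the scatter), a move towards higher toxicity in this test. For this pair, the higher number goes with the 4-carbamoylbutyl chain, and bare hydrogen on this nitrogen does not preserve it. No measured property among the data shown bears on this step.

As far as these compounds go, whether the step follows the chain itself or the carbamoyl group it carries stays open: a plain butyl chain, a shorter chain, or a carboxylic acid or an amine in place of the carbamoyl group would separate the two. Compound 1 gives < 56.1 uM, a limit of the assay and not a number, so the step cannot be followed on its core.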